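Changing the amide side chain of compound 2

The compounds below may be only part of what the source reports. "The series", "measured", "known", "first", "only" and "open" are said of these compounds alone.

Of the compounds shown here, three have been measured. Compound 1, `CCCC(=O)OCSc1ccc(OC(F)(F)F)cc1C(=O)NC(C)(C)C(N)=O`, gives in an ADME assay on CEM-SS cells (Homo sapiens) for cytotoxicity, read by XTT assay, with a stated time of 6 days (a lower number here means that less compound is tolerated, a higher number that more compound is tolerated), a limit of < 56.1 uM. Compound 2, `CCCC(=O)OCSc1ccccc1C(=O)NCCCCCCNC(C)=O`, gives 8 uM. Compound 3, `CCCC(=O)OCSc1ccccc1C(=O)Nc1ccc(C(N)=O)cc1`, gives 39 uM.

Among the two numbers actually reported, compound 2 stands lowest, and the gap to compound 3 lies beyond the usual scatter, so compound 2 is the least tolerated of the two. Compound 1 adds only a limit, (the limit of < 56.1 uM in this assay, at which 1 of the 3 values shown sits), and no number.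

Compound 4, `CCCC(=O)OCSc1ccccc1C(=O)NCC(=O)NCC(=O)OC`, has not yet been measured. It keeps the shared core of compound 2 and differs in one place: ((methoxycarbonyl)methyl)carbamoyl in place of 5-acetamidopentyl on a saturated chain carbon bound to an amide-type nitrogen. Among the measured compounds shown here, no measured step of this kind exists among the three compounds, so the expectation rests on the structural change alone and on where compound 2 stands. The writer expects the step of a 3.1-fold higher number from compound 2 to compound 4 (0.49 log units; beyond the scatter) to run toward a higher number, likely beyond the scatter. Compound 4 is therefore estimated at 25 uM, with a range from 8 uM to 70 uM.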

Compound 4, half-maximal toxic concentration: > 100 uM
Compound 4 gave a limit, no number; the forecaster's own chance of this, stated with the estimate: 30%; middle value at least 4.0-fold (0.60 log units) away from the limit.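

In this assay, among the compounds shown here, ((methoxycarbonyl)methyl)carbamoyl in place of 5-acetamidopentyl on a saturated chain carbon bound to an amide-type nitrogen gives a large step (an at least 12-fold higher number from compound 2 to compound 4 (1.09 log units; beyond the scatter)), the first one-place comparison in this set. It shows that, with the shared core unchanged, this side chain alone can move the tolerated concentration far beyond the scatter. Compound 4 gives a limit and not a number, so the step has a lower bound but no known full size: the limit of > 100 uM in this assay, at which 1 of the 4 values shown sits.

The compounds shown leave open which part of the ((methoxycarbonyl)methyl)carbamoyl group goes with the step, and whether a carboxylic acid in place of its methyl ester would read the same. They also leave open how a free amine in place of the acetamide of the 5-acetamidopentyl chain would stand in this assay.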